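A trifluoromethyl swap at the limit of a cytotoxicity read-out

The source may hold more compounds than are shown below. What is called first, only, known or untested is meant among the compounds shown, and "the series" means these compounds.

Compounds measured in an ADME assay on HaCaT cells (Homo sapiens) for cytotoxicity, read by MTT assay, with a stated time of 48 h (on this read-out higher numbers stand for weaker inhibition and lower numbers for stronger inhibition), with their values, each a limit and not a number
Compound 1 `Fc1ccc(-c2nn(-c3ccccc3)cc2-c2nc3cc(C(F)(F)F)ccc3[nH]2)cc1` gives > 50000 nM as a limit
Compound 2 `COc1ccc(-c2nn(-c3ccccc3)cc2-c2nc3cc(F)ccc3[nH]2)cc1` gives > 50000 nM as a limit
Compound 3 `COc1ccc(-c2nn(-c3ccccc3)cc2-c2nc3cc(Cl)ccc3[nH]2)cc1` gives > 50000 nM as a limit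
Compound 4 `COc1ccc(-c2nn(-c3ccccc3)cc2-c2nc3cc(C(F)(F)F)ccc3[nH]2)cc1` has not yet been measured

Compound 3 has no number in this assay and stands only at its limit of > 50000 nM in this series. Going by the values given here, the series so far offers the limit of > 50000 nM in this assay, at which 3 of the 3 values shown sit, and no reading that can be placed on a scale.

Compound 4 carries trifluoromethyl in place of chloro on an aromatic carbon of the shared core trifluoromethyl in place of chloro on an aromatic carbon and the rest of compound 3 stays as it is. The nearest measured change is a step that the two limits leave unreadable from compound 2 to compound 3 and it offers no size to carry over. Compound 4 shares trifluoromethyl with compound 1, whose value of > 50000 nM is a limit.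

With nothing readable to go on, no step beyond the scatter is expected in this assay and no direction can be named. The expected change is a number no higher from compound 3 to compound 4 (the limit leaves the size open) as an estimate and no more. Compound 4 is expected at about 50000 nM with an estimated range from 25000 nM to 100000 nM and the assay will probably report a limit once again.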

Compound 4, half-maximal inhibitory concentration: > 50000 nM
Compound 4: a limit, no number; the forecaster's own chance of this, stated with the estimate: 85%; the middle value sits exactly at the limit.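

Compound 4 joins compound 1, compound 2 and compound 3 at a limit in this assay, so none of the steps among them can be read: the limit of > 50000 nM in this assay, at which 4 of the 4 values shown sit.

The compounds shown leave open whether exchanging fluoro, chloro, trifluoromethyl or methoxy on the shared core changes the result in this assay at all, and none of them has a number to place on a scale.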